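Benzyloxycarbonyl in place of tert-butoxycarbonyl in cell tolerance

The source may report more compounds than this note shows. Statements on the series, on what has been measured and on what is new or still open speak of the compounds shown alone.

Measured so far:
compound 1 `COC(=O)C[C@H](NC(=O)OC(C)(C)C)C(=O)N(C1CC1)C1(C(=O)NCc2ccccc2)CCN(Cc2ccccc2)CC1`: 84000 nM
compound 2 `COC(=O)C[C@H](NC(=O)OC(C)(C)C)C(=O)N(Cc1cccc(F)c1)C1(C(=O)NCc2ccccc2)CCN(Cc2ccccc2)CC1`: 47000 nM

Both numbers come from an ADME assay on MDCK cells (Canis lupus familiaris) for cytotoxicity, read by microscopy, with a stated time of 72 h; a lower number here means that less compound is tolerated, a higher number that more compound is tolerated. Compound 1 stands at the higher of the two numbers shown, although compound 2 lies within the scatter of it: a 1.8-fold lower number from compound 1 to compound 2 (0.25 log units; within the scatter). That step is the only one measured, and it alters a different place, the amide-type nitrogen, so it bears only loosely on the change now in question. Compound 3 `COC(=O)C[C@H](NC(=O)OCc1ccccc1)C(=O)N(C1CC1)C1(C(=O)NCc2ccccc2)CCN(Cc2ccccc2)CC1` differs from compound 1 in one place: benzyl in place of tert-butyl on an oxygen next to a carbonyl group. Going by the values given here, no measured step touches that oxygen, so nothing in the data points to a move in either direction beyond the scatter. Compound 3 is therefore expected to stay close to compound 1, with no change at the digits printed from compound 1 to compound 3 (within the scatter) meaning no step beyond the scatter. The estimate for compound 3 is 84000 nM, expected to fall between 40000 nM and 170000 nM.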

Compound 3, minimum cytotoxic concentration: 20000 nM
Estimate against measurement, compound 3: 4.2-fold (0.62 log units) above; measured number outside the range, below it.
By their numbers in this assay, from the lowest: compound 3; then compounds 2 and 1 (each within the scatter of the next).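

In this assay, the oxygen next to a carbonyl group proves to be a place where the number responds: benzyl in place of tert-butyl gives a 4.2-fold lower number from compound 1 to compound 3 (0.62 log units; beyond the scatter), so less compound is tolerated with benzyloxycarbonyl than with tert-butoxycarbonyl. The only earlier step, a 1.8-fold lower number from compound 1 to compound 2 (0.25 log units; within the scatter), altered the amide-type nitrogen and stayed within the scatter, so this is the first step shown that goes beyond it. Nothing measured here says what lies behind this shift.

As far as these compounds go, whether the lower number follows the aromatic ring or simply the larger group remains open, and a cyclohexylmethyl group on the same oxygen would separate the two. From the compounds shown here alone, it is also open whether benzyl in place of tert-butyl has a similar effect when 3-fluorobenzyl, as in compound 2, stands on the amide-type nitrogen instead of cyclopropyl.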